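Chlorophenyl positional isomers on the shared core

A few compounds are considered here, and "the series" means these few. Any claim that something is new, unique, unknown or untested is made for them only; others in the source may bear on it.

Of the compounds shown here, three on the shared core have been measured in a functional assay on T47D cells (Homo sapiens) for cytotoxicity, read by CCK-8 assay and cell counting, with a stated time of 2 days; a higher number here means a weaker inhibitor, a lower number a stronger inhibitor. Compound 1 `Oc1ccc(-c2cc(-c3ccccc3)nc(-c3ccccc3Cl)c2)cc1` gives 5460 nM. Compound 2 `Oc1ccc(-c2cc(-c3cccc(Cl)c3)nc(-c3ccccn3)c2)cc1` gives 27900 nM. Compound 3 `Oc1ccc(-c2cc(-c3ccccc3)nc(-c3ccc(Cl)cc3)c2)cc1` gives 4270 nM, the lowest of the three numbers, though compound 1 sits within the scatter of it and only compound 2 lies beyond it. For the measured compounds named here, the one measured step of this type is a 1.3-fold lower number from compound 1 to compound 3 (0.11 log units; within the scatter), so the two chlorophenyl placements tried so far return numbers within the scatter of each other.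

Compound 4 `Oc1ccc(-c2cc(-c3ccccc3)nc(-c3cccc(Cl)c3)c2)cc1` is not yet measured. Relative to compound 3 the change is 3-chlorophenyl in place of 4-chlorophenyl on an aromatic carbon. The step from compound 1 to compound 3 is the one that bears on it, and it was within the scatter. Compound 2 also carries a 3-chlorophenyl group but differs from compound 4 elsewhere too, so its number is noted without being read as a step. For compound 4 a step of a 1.3-fold higher number from compound 3 to compound 4 (0.11 log units; within the scatter) is therefore expected, nothing beyond the scatter. The estimate for compound 4 in this assay is 5500 nM, with a range of 2200 nM to 14000 nM.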

Compound 4, half-maximal inhibitory concentration: 4790 nM
Beside the measured number, compound 4's estimate is 1.1-fold (0.06 log units) above it, and the stated range covers the measured number.
By their numbers in this assay, from the lowest: compounds 3, 4 and 1 (each within the scatter of the next); then compound 2.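

In this assay, 3-chlorophenyl in place of 4-chlorophenyl gives a 1.1-fold higher number from compound 3 to compound 4 (0.05 log units; within the scatter), and 3-chlorophenyl in place of 2-chlorophenyl gives a 1.1-fold lower number from compound 1 to compound 4 (0.06 log units; within the scatter), so all three chlorophenyl placements at this position next to the ring nitrogen now lie within the scatter of one another. Phenyl in place of pyridin-2-yl gives a 5.8-fold lower number from compound 2 to compound 4 (0.77 log units; beyond the scatter), the first single-place step in the series beyond the scatter, and it comes from changing the ring rather than moving the chlorine. No measurement on hand accounts for either outcome.

As far as these compounds go, it remains open whether an amine or a carboxylic acid on this phenyl ring would also stay within the scatter of the chlorophenyl compounds. Also open, from the compounds shown here alone, is whether the pyridin-2-yl step would recur alongside the other chlorophenyl placements.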